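The source may hold more compounds than are shown below. What is called first, only, known or untested is meant among the compounds shown, and "the series" means these compounds.

Measured so far in a functional assay on PC-3 cells (Homo sapiens) for inhibition, read by MTT assay, with a stated time of 72 h; a lower number here means a stronger inhibitor, a higher number a weaker inhibitor:
compound 1 `O=C(CSc1nc(Nc2ccccc2)c2ccccc2n1)Nc1ccccc1Br`, 19800 nM
compound 2 `CCc1cccc(NC(=O)CSc2nc(Nc3ccccc3)c3ccccc3n2)c1`, 11000 nM
compound 3 `CCc1ccc(NC(=O)CSc2nc(Nc3ccccc3)c3ccccc3n2)cc1`, 17900 nM

Compound 3 sits second highest of the three numbers; its steps to the others, a 1.1-fold lower number from compound 1 to compound 3 (0.04 log units; within the scatter) and a 1.6-fold higher number from compound 2 to compound 3 (0.21 log units; within the scatter), are both within the scatter, as is a 1.8-fold lower number from compound 1 to compound 2 (0.26 log units; within the scatter). Compound 4 `O=C(CSc1nc(Nc2ccccc2)c2ccccc2n1)Nc1ccc(Cl)c(Cl)c1` differs from compound 3 by 3,4-dichlorophenyl in place of 4-ethylphenyl on an amide-type nitrogen. The measured steps that bear on this change are those exchanging the group on the amide-type nitrogen, a bromine-bearing phenyl against ethylphenyl, and none of them left the scatter. On that basis compound 4 is expected to show no step beyond the scatter in this assay, an estimated step of a 1.2-fold lower number from compound 3 to compound 4 (0.08 log units; within the scatter). The estimate for compound 4 is 15000 nM, with a range from 5000 nM to 45000 nM.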

Compound 4, half-maximal inhibitory concentration: 12100 nM
Estimate against measurement, compound 4: 1.2-fold (0.09 log units) above, and the stated range covers the measured number.
By their numbers in this assay, from the lowest: compounds 2, 4, 3 and 1 (each within the scatter of the next).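

Compound 4 puts two chlorines on the phenyl on the amide-type nitrogen, and in this assay the numbers show a 1.5-fold lower number from compound 3 to compound 4 (0.17 log units; within the scatter) and a 1.1-fold higher number from compound 2 to compound 4 (0.04 log units; within the scatter) and a 1.6-fold lower number from compound 1 to compound 4 (0.21 log units; within the scatter) with all three inside the scatter. 3,4-Dichlorophenyl thus joins 2-bromophenyl, 3-ethylphenyl and 4-ethylphenyl in one undivided band, and no exchange at this position has yet separated any of these four groups. No supporting measurement offers a reason for this flatness.

On these data alone, whether a carboxylic acid, an amine or a longer alkyl chain on this phenyl would move the number beyond the scatter stays open. So does the outcome of any change away from this position, on the shared core.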